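Halogen swap on the anilino ring of compound 3

This account rests on a few compounds, and the source may have more. Where it says the series, first, only, none or still open, it means among the compounds named here.

Among the compounds with values here, compound 3 `N#Cc1c(Nc2ccc(Cl)cc2)nc(SCc2cn(Cc3ccccc3Cl)nn2)nc1-c1ccccc1` is the one member of the series with a number in a functional assay on ECa-109 cells (Homo sapiens) for inhibition, read by MTT assay, with a stated time of 72 h; a higher number here means a weaker inhibitor, a lower number a stronger inhibitor: compound 3 gives 1420 nM. Compound 1 `C#CCSc1nc(Nc2cccc(C(F)(F)F)c2)c(C#N)c(-c2ccccc2)n1` reaches only a limit in this assay, > 128000 nM. Compound 2 `C#CCSc1nc(Nc2ccccc2Cl)c(C#N)c(-c2ccccc2)n1` likewise stops at a limit, > 128000 nM. Two of the three values therefore sit at the limit (the limit of > 128000 nM in this assay, at which 2 of the 3 values shown sit), leaving compound 3 as the sole anchor. Compound 4 `N#Cc1c(Nc2ccc(F)cc2)nc(SCc2cn(Cc3ccccc3Cl)nn2)nc1-c1ccccc1` differs from compound 3 by fluoro in place of chloro on an aromatic carbon. Within the data shown here, no measured step covers this change, so nothing sizes it; a shift within the usual scatter, with a slight lean to weaker inhibition, is expected. Compound 4 is accordingly expected at 2200 nM, between 700 nM and 7000 nM, an estimated step of a 1.5-fold higher number from compound 3 to compound 4 (0.19 log units; within the scatter).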

Compound 4, half-maximal inhibitory concentration: 25800 nM
Compound 4: the middle estimate sits 12-fold (1.07 log units) below what was measured; the measured number lies above the stated range.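

In this assay, within the data shown here, the exchange of fluoro for chloro gives an 18-fold higher number from compound 3 to compound 4 (1.26 log units; beyond the scatter), the first sized step. The (4-chlorophenyl)amino group is therefore not interchangeable with the (4-fluorophenyl)amino group, and a single halogen at this position can carry a large change. Nothing measured on these compounds accounts for the size of the step.

Going by these compounds, whether bromo, methyl or methoxy at the same place would match compound 3 or improve on it stays open. One pair also leaves open whether the same exchange on the other chlorine-bearing ring of compound 3 would give a step of similar size.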